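A few compounds are considered here, and "the series" means these few. Any claim that something is new, unique, unknown or untested is made for them only; others in the source may bear on it.

Measured compounds:
- Compound 1 `Cc1ccc2c(c1)[n+]([O-])c(NCCN(C)C)n[n+]2[O-]` gives > 51000000 nM in a physicochemical assay for solubility, in the presence of a further agent that is not named here; a lower number here means a less soluble compound, a higher number a more soluble compound; that value is a limit of the assay, not a number.
- Compound 2 `CCc1ccc2c(c1)[n+]([O-])c(NCCN(C)C)n[n+]2[O-]` gives > 49000000 nM in this assay; that value too is a limit of the assay.
- Compound 3 `CN(C)CCNc1n[n+]([O-])c2ccc(C(C)(C)C)cc2[n+]1[O-]` gives 38000000 nM in this assay, the only true number among the three.

Going by the values given here, compound 3 thus stands as the one compound with a readable value, the other two sitting at the assay's ceiling. The step from compound 1 to compound 2 cannot be sized because the limit of > 51000000 nM in this assay, at which 1 of the 3 values shown sits, and the limit of > 49000000 nM in this assay, at which 1 of the 3 values shown sits, both mark only a floor. The two steps that reach compound 3 are readable as floors: an at least 1.3-fold lower number from compound 1 to compound 3 (0.12 log units; that floor lies within the scatter) and an at least 1.2-fold lower number from compound 2 to compound 3 (0.11 log units; that floor lies within the scatter), each within the usual scatter.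

Compound 4 `CCOc1ccc2c(c1)[n+]([O-])c(NCCN(C)C)n[n+]2[O-]` has not yet been measured. It differs from compound 3 by ethoxy in place of tert-butyl on an aromatic carbon. The measured steps onto that same aromatic carbon show tert-butyl giving a number no higher than methyl or ethyl, so replacing tert-butyl by ethoxy is expected to move the number back up, at most modestly, as a 1.3-fold higher number from compound 3 to compound 4 (0.12 log units; within the scatter). Compound 4 is therefore estimated at 50000000 nM in this assay. Its expected range runs from 28000000 nM to 90000000 nM, with a real chance that only a limit is reported.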

Compound 4, solubility: > 50000000 nM
Compound 4 was reported as a limit; the forecaster's own chance of this, stated with the estimate: 50%; the middle value sits exactly at the limit.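

Ethoxy is the first group on this aromatic carbon to carry an oxygen, and in this assay compound 4 gives > 50000000 nM, which is a limit of the assay and not a number. Putting ethoxy in place of tert-butyl gives an at least 1.3-fold higher number from compound 3 to compound 4 (0.11 log units; that floor lies within the scatter), so this change shows only a floor and no step beyond the scatter. The steps to compound 4 from compound 1 and from compound 2 cannot be read, as limits stand at both ends of each.

On these data alone, the true values of compound 1, compound 2 and compound 4 stay unknown, so these three cannot be ranked against one another. As far as these compounds go, it also remains open how an amine, a carboxylic acid or a longer ether chain on this aromatic carbon would read in this assay.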